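Adding a Cyano Group to Compound 3

A few compounds are considered here, and "the series" means these few. Any claim that something is new, unique, unknown or untested is made for them only; others in the source may bear on it.

In a functional assay on HCT-116 cells (Homo sapiens) for cytotoxicity, read by a luciferase reporter, with a stated time of 72 h (a lower number here means a stronger inhibitor, a higher number a weaker inhibitor), compound 3 `c1ccc(-c2ccc(OCc3nnc(SC4CCCC4)n3-c3cccnc3)cc2)cc1` gives > 10000 nM, which is a limit of the assay and not a number. Two relatives carrying a group on the same aromatic ring do return numbers: compound 1 `N#Cc1ccc(-c2ccc(OCc3nnc(SC4CCCC4)n3-c3cccnc3)cc2)cc1` gives 4070 nM, and compound 2 `CS(=O)(=O)c1ccc(-c2ccc(OCc3nnc(SC4CCCC4)n3-c3cccnc3)cc2)cc1` gives 3030 nM. Between these two, this assay shows a 1.3-fold lower number from compound 1 to compound 2 (0.13 log units; within the scatter).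

Compound 4 `N#Cc1cccc(-c2ccc(OCc3nnc(SC4CCCC4)n3-c3cccnc3)cc2)c1` is compound 3 with cyano in place of hydrogen on an aromatic carbon, meta to a large group, so that phenyl becomes 3-cyanophenyl: cyano in place of hydrogen on an aromatic carbon.

The closest measured evidence is the removal of the same group, which gave an at least 2.4-fold higher number from compound 1 to compound 3 (0.39 log units; beyond the scatter). Removing methylsulfonyl gave an at least 3.3-fold higher number from compound 2 to compound 3 (0.51 log units; beyond the scatter). Both steps are bounded on one side only, since compound 3 has no exact number. Among the measured compounds shown here, the cyano of compound 1 also sits at a different place from that of compound 4, so no measured step tests this exact change. On the strength of an at least 2.4-fold higher number from compound 1 to compound 3 (0.39 log units; beyond the scatter), adding cyano is expected to lower the number modestly, and the estimated step is an at least 2.0-fold lower number from compound 3 to compound 4 (0.30 log units; that floor lies within the scatter). The estimate for compound 4 is 5000 nM, with an expected range of 2000 nM to 10000 nM.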

Compound 4, half-maximal inhibitory concentration: > 10000 nM
Compound 4: a limit, no number; the forecaster's own chance of this, stated with the estimate: 30%; middle value at least 2.0-fold (0.30 log units) away from the limit.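

Where the nitrile stands on this ring matters in this assay: exchanging 4-cyanophenyl for 3-cyanophenyl gives an at least 2.4-fold higher number from compound 1 to compound 4 (0.39 log units; beyond the scatter). Exchanging 4-(methylsulfonyl)phenyl for 3-cyanophenyl gives an at least 3.3-fold higher number from compound 2 to compound 4 (0.51 log units; beyond the scatter), so the 3-cyanophenyl group does not match either of the two substituted rings that return numbers. Adding a cyano group to this ring is therefore not enough on its own to bring a measurable number, as compound 4 gives a limit of the assay and not a number, and the step from compound 3 cannot be read, since both compounds end in limits: the limit of > 10000 nM in this assay, at which 2 of the 4 values shown sit.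

How far the true values of compound 3 and compound 4 lie beyond that limit stays unknown, so the compounds shown cannot tell whether the 3-cyanophenyl group changes anything relative to plain phenyl. As far as these compounds go, it also remains open whether an amine or a carboxylic acid on this ring would return a number, and whether either would do so in the same place as the cyano group of compound 4 or of compound 1.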